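Aryl urea series: antiproliferative notes and one estimate

The source may hold more compounds than are shown below. What is called first, only, known or untested is meant among the compounds shown, and "the series" means these compounds.

Measured compounds in a functional assay on PC-3 cells (Homo sapiens) for antiproliferative activity, read by MTT assay, with a stated time of 48 h; a higher number here means a weaker inhibitor, a lower number a stronger inhibitor:
compound 1 `O=C(Nc1ccccc1)Nc1nnc(Sc2ncnc3scc(-c4ccncc4)c23)s1` gives 5700 nM
compound 2 `O=C(Nc1cccc(C(F)(F)F)c1)Nc1nnc(Sc2ncnc3scc(-c4ccncc4)c23)s1` gives 11500 nM
compound 3 `O=C(Nc1ccc(Cl)cc1)Nc1nnc(Sc2ncnc3scc(-c4ccncc4)c23)s1` gives 7700 nM

Compound 4 `O=C(Nc1ccc(Cl)c(C(F)(F)F)c1)Nc1nnc(Sc2ncnc3scc(-c4ccncc4)c23)s1` has not yet been measured. The change from compound 3 to compound 4 is trifluoromethyl in place of hydrogen on an aromatic carbon. The same change has been made once before in this set, from compound 1 to compound 2, where it reads trifluoromethyl in place of hydrogen on an aromatic carbon and gave a 2.0-fold higher number from compound 1 to compound 2 (0.30 log units; within the scatter). The two cores on which the change is made differ as follows: chloro in place of hydrogen on an aromatic carbon. The surroundings of the place are not identical: in compound 4 the entering group sits ortho to a chloro group (1 heavy atom) as well as meta to a large group, whereas in compound 2 it is meta to a large group only, so this is the same kind of change rather than the same change. Between compound 2 and compound 3 the step is a 1.5-fold lower number from compound 2 to compound 3 (0.17 log units; within the scatter).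

For this assay the step from compound 3 to compound 4 is expected to be a 1.8-fold higher number from compound 3 to compound 4 (0.26 log units; within the scatter), placed beside a 2.0-fold higher number from compound 1 to compound 2 (0.30 log units; within the scatter). Within the data shown here, this expectation rests on a 2.0-fold higher number from compound 1 to compound 2 (0.30 log units; within the scatter), the only precedent in the set; that step lies within the scatter, and no measured compound points to a larger movement. Compound 4 is therefore estimated at 14000 nM, with a range from 6000 nM to 35000 nM.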

Compound 4, half-maximal inhibitory concentration: 12100 nM
Beside the measured number, compound 4's estimate is 1.2-fold (0.06 log units) above it; the measured number falls inside the stated range.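

In this assay the trifluoromethyl change carries from the core of compound 1 to the core of compound 3 without a readable difference in size, the new step being (a 1.6-fold higher number from compound 3 to compound 4 (0.20 log units; within the scatter)) and the comparison with its precedent as follows: the same change on two cores in this assay, a 2.0-fold higher number (0.30 log units; within the scatter) from compound 1 to compound 2 and a 1.6-fold higher number (0.20 log units; within the scatter) from compound 3 to compound 4, 1.3-fold (0.11 log units) apart, within the scatter of two such steps.
The chloro change, read on the core of compound 2 (a 1.1-fold higher number from compound 2 to compound 4 (0.02 log units; within the scatter)), likewise agrees with its earlier step on the core of compound 1: the same change on two cores in this assay, a 1.4-fold higher number (0.13 log units; within the scatter) from compound 1 to compound 3 and a 1.1-fold higher number (0.02 log units; within the scatter) from compound 2 to compound 4, 1.3-fold (0.11 log units) apart, within the scatter of two such steps.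
Only the full replacement of phenyl by 4-chloro-3-(trifluoromethyl)phenyl passes the scatter, and then modestly (a 2.1-fold higher number from compound 1 to compound 4 (0.33 log units; beyond the scatter)), so these pairs show agreement between small steps on closely related cores but do not show that either change would transfer to other cores or at a larger size.

As far as these compounds go, what a methoxy group, an amine or a carboxylic acid on the phenyl ring would do to the number remains open. From the compounds shown here alone, each comparison rests on a single pair of steps, and whether any change to the shared core alters the picture also remains open.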